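This account rests on a few compounds, and the source may have more. Where it says the series, first, only, none or still open, it means among the compounds named here.

Measured compounds:
- compound 1 `O=C1N=C(N2N=C(c3ccccc3)CC2c2ccccc2O)S/C1=C1/C(=O)Nc2ccccc21`: 2410 nM
- compound 2 `O=C1N=C(N2N=C(c3ccccc3)CC2c2ccccc2O)S/C1=C1/C(=O)Nc2ccc(Br)cc21`: 280 nM
- compound 3 `Cc1ccc2c(c1)/C(=C1\SC(N3N=C(c4ccccc4)CC3c3ccc(Cl)cc3)=NC1=O)C(=O)N2`: 260 nM

All three were tested in a functional assay on cells (Cancer cell lines, Homo sapiens) for cytotoxicity, read by sulforhodamine B assay, with a stated time of 48 h; a higher number here means a weaker inhibitor of growth, a lower number a stronger inhibitor of growth. Among the measured compounds shown here, compound 2 holds the second highest of the three numbers: its value and that of compound 3 lie within the scatter of one another, while compound 1 sits well above it, as the step of an 8.6-fold lower number from compound 1 to compound 2 (0.93 log units; beyond the scatter) shows; that step, a bromo in place of hydrogen on an aromatic carbon, is the only single-change step among the measured compounds.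

Compound 4 `CN(C)c1ccc(C2CC(c3ccccc3)=NN2C2=NC(=O)/C(=C3\C(=O)Nc4ccc(Br)cc43)S2)cc1` is the next compound. It differs from compound 2 by 4-(dimethylamino)phenyl in place of 2-hydroxyphenyl on a saturated ring carbon. For the measured compounds named here, no measured step changes this part of the shared core, so there is no direct precedent. Compound 3, which carries a 4-chlorophenyl on that same ring carbon alongside a different substituent elsewhere, gives a number close to compound 2, which hints that exchanging this aryl group need not move the value far. The step from compound 2 to compound 4 is therefore expected to be small, a 1.1-fold higher number from compound 2 to compound 4 (0.06 log units; within the scatter), within or just beyond the scatter in either direction. For compound 4 the expected value in this assay is 320 nM, with a likely range from 100 nM to 1000 nM.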

Compound 4, concentration for 50% growth inhibition: 250 nM
Beside the measured number, compound 4's estimate is 1.3-fold (0.11 log units) above it; measured number inside the range.
By their numbers in this assay, from the lowest: compounds 4, 3 and 2 (each within the scatter of the next); then compound 1.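

In this assay, replacing 2-hydroxyphenyl with 4-(dimethylamino)phenyl on the saturated ring carbon gives a 1.1-fold lower number from compound 2 to compound 4 (0.05 log units; within the scatter), so this pair cannot be told apart. Among the compounds shown here, this is the first direct reading at this position: with the bromo group held in place, an aryl group with two more heavy atoms and no hydrogen-bond donor leaves the number within the scatter, so in this pair the hydroxyl hydrogen is not needed to keep the value. No supporting measurement is available to explain this result.

The compounds shown leave open whether the same exchange would give a similar result on the core of compound 1, which lacks the bromo group. They also leave open how a non-aromatic group such as cyclohexyl, or a phenyl carrying a carboxylic acid, would behave on this carbon.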